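From compound 2 to compound 3: a phenyl group exchanged

The source may hold more compounds than are shown below. What is called first, only, known or untested is meant among the compounds shown, and "the series" means these compounds.

In an ADME assay on MCF7-DOX cells (Homo sapiens) for cytotoxicity, read by MTT assay, with a stated time of 48 h (on this read-out higher numbers stand for weaker inhibition and lower numbers for stronger inhibition), compound 1 (`COc1cc(OC)c(C(=O)/C=C/c2cccc(N3CCNCC3)c2)c(O)c1CC=C(C)C`) gives 99900 nM and compound 2 (`COc1cc(OC)c(C(=O)/C=C/c2cccc(C(F)(F)F)c2)c(O)c1CC=C(C)C`) gives 66600 nM, so compound 2 stands level with compound 1 within the scatter. Compound 3 (`COc1cc(OC)c(C(=O)/C=C/c2ccc(F)cc2)c(O)c1CC=C(C)C`) differs from compound 2 as follows: 4-fluorophenyl in place of 3-(trifluoromethyl)phenyl on a double-bonded chain carbon bound to a double-bonded chain carbon. Going by the values given here, the only measured step, a 1.5-fold lower number from compound 1 to compound 2 (0.18 log units; within the scatter), exchanges piperazin-1-yl for trifluoromethyl and stays within the scatter. Among the compounds with values here, no measured compound carries 4-fluorophenyl. The expected change is therefore a 1.1-fold lower number from compound 2 to compound 3 (0.05 log units; within the scatter), which is no step beyond the scatter. Compound 3 is estimated at 60000 nM, with an expected range of 25000 nM to 120000 nM.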

Compound 3, half-maximal inhibitory concentration: 53700 nM
Compound 3: the middle estimate sits 1.1-fold (0.05 log units) above what was measured, within the range that was stated.
By their numbers in this assay, from the lowest: compounds 3, 2 and 1 (each within the scatter of the next).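

In this assay, 4-fluorophenyl in place of 3-(trifluoromethyl)phenyl on a double-bonded chain carbon bound to a double-bonded chain carbon gives a 1.2-fold lower number from compound 2 to compound 3 (0.09 log units; within the scatter). This position therefore tolerates an exchange of the whole aryl group, including the fluorinated substituent, without a step beyond the scatter. No available evidence bears on this result.

As far as these compounds go, whether an amine or a carboxylic acid on this phenyl group would give a step beyond the scatter remains open. Also open, from the compounds shown here alone, is whether a change to the shared core would separate these compounds in this assay.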